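The source may report more compounds than this note shows. Statements on the series, on what has been measured and on what is new or still open speak of the compounds shown alone.

Compound 1 `CC(c1cc2cccnc2cc1F)n1cnc2ncc(-c3ccccc3)nc21` gives 570 nM in a functional assay on NCI-H1993 cells (Homo sapiens) for inhibition, read by CCK-8 assay, with a stated time of 72 h; a higher number here means a weaker inhibitor, a lower number a stronger inhibitor.
Compound 2 `CCC(c1cc2cccnc2cc1F)n1cnc2ncc(-c3ccccc3)nc21` gives "not determined" (no result reported) in this assay.

Compound 2 carries an ethyl chain where compound 1 has a methyl, but compound 2 stands without a number in this assay, so nothing can be said about where it lies against compound 1. Compound 3 `CCC(c1cc2cccnc2cc1F)n1cnc2ncc(-c3ccc(C(N)=O)c(F)c3)nc21` keeps the ethyl chain of compound 2 and differs from it in one place: 4-carbamoyl-3-fluorophenyl in place of phenyl on an aromatic carbon. Without a measured neighbour in this assay for this change, the step from compound 2 to compound 3 cannot be sized from shown numbers; a shift beyond the scatter toward a stronger inhibitor is expected, but only loosely. Compound 3 is expected to give about 150 nM, within 30 nM to 900 nM.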

Compound 3, half-maximal inhibitory concentration: 226 nM
Estimate against measurement, compound 3: 1.5-fold (0.18 log units) below; the range from low to high includes it.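

Among the compounds shown here, compound 2 has no number in this assay and so no step to compound 3 can be read. No measured evidence bears on the value of compound 3. Still open, as far as these compounds go, is how far the 4-carbamoyl-3-fluorophenyl group alone shifts inhibition, and how the ethyl chain compares with the methyl of compound 1.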